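This account rests on a few compounds, and the source may have more. Where it says the series, first, only, none or still open, it means among the compounds named here.

Working notes on the series. Three compounds on the shared core have so far been run in a functional assay on MCF7 cells (Homo sapiens) for antiproliferative activity, read by MTT assay, with a stated time of 48 h; a lower number here means a stronger inhibitor, a higher number a weaker inhibitor. Compound 1 `CCOC(=O)CN(Cc1ccccc1)c1nc(NCc2cccc(OC)c2)ncc1[N+](=O)[O-]` gives 57400 nM. Compound 2 `COC(=O)CN(C)c1nc(NCc2ccccc2)ncc1[N+](=O)[O-]` gives 85900 nM, and compound 3 `CCOC(=O)CNc1nc(NCc2ccccc2)ncc1[N+](=O)[O-]` gives 52400 nM. Among these three, compound 1 holds the second highest number; the nearest value is that of compound 3 and the furthest that of compound 2, and both gaps fall within the scatter, so the three cannot be placed in any order on this read-out. Going by the values given here, the only one-place step measured so far, a 1.6-fold lower number from compound 2 to compound 3 (0.21 log units; within the scatter), also stays within the scatter.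

Compound 4 `CCOC(=O)CN(Cc1ccccc1)c1nc(Nc2ccccc2)ncc1[N+](=O)[O-]` is the next member. Compared with compound 1 the change is phenyl in place of 3-methoxybenzyl on a nitrogen on an aromatic ring, read one bond further out as (3-methoxybenzyl)amino to anilino. Among the compounds with values here, no measured step bears on this substituent: the single step available concerns a different part of the core and is itself within the scatter, so the data give no reason to expect a shift beyond the scatter in this assay in either direction. The step of a 1.0-fold higher number from compound 1 to compound 4 (0.02 log units; within the scatter) is therefore expected to lie within the scatter. Compound 4 is estimated at 60000 nM, with a range from 25000 nM to 150000 nM.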

Compound 4, half-maximal inhibitory concentration: > 100000 nM
Compound 4: a limit, no number; the forecaster's own chance of this, stated with the estimate: 15%; at least 1.6-fold (0.22 log units) between middle value and limit.
By their numbers in this assay, from the lowest: compounds 3, 1 and 2 (each within the scatter of the next). At a limit, above all of these: compound 4.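

In this assay compound 4 reads only as a limit, > 100000 nM, and not as a number. Phenyl in place of 3-methoxybenzyl on a nitrogen on an aromatic ring gives an at least 1.7-fold higher number from compound 1 to compound 4 (0.24 log units; that floor lies within the scatter), the first measured step at this position; only a floor is known for it, so the true step may lie within the scatter or well beyond it. The earlier compounds gave no reading of this substituent, and this position now supplies the only compound of the series that sits at the limit of the read-out: the limit of > 100000 nM in this assay, at which 1 of the 4 values shown sits.

What the compounds shown leave open is which part of the change matters, the loss of the methoxy group or the loss of the carbon link between the ring and the nitrogen; a 3-methoxyphenyl or a 2-phenylethyl on that nitrogen, with the rest of compound 1 kept, would separate the two. On these data alone, the size of the step also stays open, as does whether any group at this position can bring the number below that of compound 1.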